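Removing a chloro group on a hydroxamic acid chain

This account rests on a few compounds, and the source may have more. Where it says the series, first, only, none or still open, it means among the compounds named here.

Compound 1 `C#CCN(C)CCCOc1cc(NC(=O)CCCCCCCCC(=O)NO)ccc1Cl`: 2480 nM
Compound 2 `C#CCN(C)CCCOc1cc(NC(=O)CCCCCCCC(=O)NO)ccc1Cl`: 1120 nM
Compound 3 `C#CCN(C)CCCOc1cc(NC(=O)CCCCCCC(=O)NO)c(Cl)cc1Cl`: 1780 nM

In an assay on isolated protein for inhibition of histone deacetylase 8 (Homo sapiens), read by fluorescence (on this read-out higher numbers stand for weaker inhibition and lower numbers for stronger inhibition), compound 3 gives 1780 nM, the second highest of the three numbers, within the usual scatter of both compound 1 and compound 2. Compound 4 `C#CCN(C)CCCOc1cc(NC(=O)CCCCCCC(=O)NO)ccc1Cl` differs from compound 3 by hydrogen in place of chloro on an aromatic carbon, ortho to a large group, meta to a chloro group and para to a 3-(methyl(propargyl)amino)propoxy group. Among the measured compounds shown here, the single measured step, a 2.2-fold lower number from compound 1 to compound 2 (0.35 log units; beyond the scatter), changes the chain and not the ring, so no measured step bears directly on this change. Compound 4 is therefore expected to show no step beyond the scatter, a 1.1-fold lower number from compound 3 to compound 4 (0.05 log units; within the scatter). The estimate for compound 4 is 1600 nM, with a range from 600 nM to 4500 nM.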

Compound 4, half-maximal inhibitory concentration: 50 nM
The estimate for compound 4 lay 32-fold (1.51 log units) above the measured number, outside the stated range (below it).
By their numbers in this assay, from the lowest: compound 4; then compounds 2, 3 and 1 (each within the scatter of the next, the first and the last beyond it).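

In this assay, hydrogen in place of chloro on this aromatic carbon matters greatly at this chain length, with a 36-fold lower number from compound 3 to compound 4 (1.55 log units; beyond the scatter). Chain length also matters far more here than the earlier 2.2-fold lower number from compound 1 to compound 2 (0.35 log units; beyond the scatter) suggested, as the shorter chain gives a 22-fold lower number from compound 2 to compound 4 (1.35 log units; beyond the scatter) and a 50-fold lower number from compound 1 to compound 4 (1.70 log units; beyond the scatter). Nothing available here accounts for the size of these steps.

From the compounds shown here alone, whether chloro on this carbon has a similar effect on the two longer chains remains open. So does how a methoxy group or an amine there would compare with hydrogen.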